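The compounds below may be only part of what the source reports. "The series", "measured", "known", "first", "only" and "open" are said of these compounds alone.

Compound 1 `CC1CCN(c2c(S(=O)(=O)c3ccc(F)c(Cl)c3)cnc3cc(Cl)ccc23)CC1`: 94%
Compound 2 `CC1CCN(c2c(S(=O)(=O)c3ccc(F)cc3)cnc3ccc(Cl)cc23)CC1`: 89%

In an assay on isolated protein for displacement of a labelled ligand from metabotropic glutamate receptor 5 (Homo sapiens), with a stated time of 60 min, tested at 1 uM (on this read-out lower numbers stand for less inhibition and higher numbers for more inhibition at the one concentration tested (going by the name of the read-out)), compound 1 gives 94%, and compound 2 gives 89%; the two values lie within the usual scatter of each other, so neither stands apart from the other. Compound 3 `COc1cccc(S(=O)(=O)c2cnc3cc(Cl)ccc3c2N2CCC(C)CC2)c1` has not yet been measured. It differs from compound 1 in one place: 3-methoxyphenyl in place of 3-chloro-4-fluorophenyl on a sulfonyl sulfur. Going by the values given here, no measured pair shows this kind of change, so the size of its effect is open. Compound 3 is expected to show somewhat less inhibition than compound 1, an estimated step of a number 14 percentage points lower from compound 1 to compound 3 (beyond the scatter) in this assay. Compound 3 is estimated at 80%, within a range from 55% to 95%.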

Compound 3, a percentage reported as inhibition, at one concentration (the size of the read-out at that concentration, not a potency): 93%
Beside the measured number, compound 3's estimate is 13 percentage points below it, within the range that was stated.
By their numbers in this assay, from the lowest: compounds 2, 3 and 1 (each within the scatter of the next).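

In this assay, the step is a number 1 percentage points lower from compound 1 to compound 3 (within the scatter), so 3-methoxyphenyl and 3-chloro-4-fluorophenyl on a sulfonyl sulfur cannot be told apart at the one concentration tested. Going by these compounds alone, this is the first measured pair with a single change at this place, and it shows that both halogens can be absent from the aryl group, and an oxygen-linked group present, without a step beyond the scatter. Nothing measured here accounts for this result. Going by these compounds, it remains open whether a longer chain such as ethoxy, or an amine or a carboxylic acid on the ring, would also keep this level of inhibition.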